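A few compounds are considered here, and "the series" means these few. Any claim that something is new, unique, unknown or untested is made for them only; others in the source may bear on it.

Working notes on the series. For the measured compounds named here, the three measured members share one core. Compound 1 `Cc1nc(C(NC(=O)C(=O)Nc2ccc(F)c(F)c2)C2CCCCN2)sc1CO` sits at a limit rather than a number in an ADME assay on TZM-b1 cells (Homo sapiens) for cytotoxicity, read by XTT assay, with a stated time of 3 days (a lower number here means that less compound is tolerated, a higher number that more compound is tolerated), giving > 87000 nM. Compound 2 `Cc1ccc(NC(=O)C(=O)NC(c2nc(C)c(CCO)s2)C2CCCCN2)c(F)c1` likewise ends at a limit in this assay, with > 78800 nM. Going by the values given here, compound 3 `Cc1nc(C(NC(=O)C(=O)Nc2ccc(Cl)c(F)c2)C2CCCCN2)sc1CO` is the only member with an actual number in this assay, 58400 nM. The other two values are limits, the limit of > 78800 nM in this assay, at which 1 of the 3 values shown sits, and (the limit of > 87000 nM in this assay, at which 1 of the 3 values shown sits).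

Among the compounds with values here, the one measured step is an at least 1.4-fold lower number from compound 1 to compound 3 (0.17 log units; that floor lies within the scatter), a chloro in place of fluoro on an aromatic carbon, and its floor lies within the scatter.

Compound 4 `Cc1ccc(NC(=O)C(=O)NC(c2nc(C)c(CO)s2)C2CCCCN2)c(F)c1` differs from compound 3 by 2-fluoro-4-methylphenyl in place of 4-chloro-3-fluorophenyl on an amide-type nitrogen. Within the data shown here, no measured step covers such an exchange of the whole substitution pattern; the step from compound 1 to compound 3 touches only a halogen, and the two values of compound 2 and compound 3 are a limit and a number, so no step can be computed from them. The step in this assay is therefore expected to be small: compound 4 is estimated to show a 1.5-fold higher number from compound 3 to compound 4 (0.16 log units; within the scatter), likely returning the assay to its limit.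

Compound 4 is expected to give about 85000 nM, within 45000 nM to 160000 nM.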

Compound 4, half-maximal cytotoxic concentration: > 88000 nM
Compound 4: only a limit was reported; the forecaster's own chance of this, stated with the estimate: 60%; middle value at least 1.0-fold (0.01 log units) away from the limit.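

The exchange of 4-chloro-3-fluorophenyl for 2-fluoro-4-methylphenyl on an amide-type nitrogen gives in this assay an at least 1.5-fold higher number from compound 3 to compound 4 (0.17 log units; that floor lies within the scatter), so a step now covers the whole substitution pattern of this aryl group and not only one halogen. Like the halogen step, it gives only a floor, which does not separate compound 3 from compound 4, and the steps from compound 1 and from compound 2 to compound 4 cannot be read, with limits at both ends. Compound 4 ends at a limit and not at a number: the limit of > 88000 nM in this assay, at which 1 of the 4 values shown sits.

For the compounds shown here, still open is where the true values of compound 1, compound 2 and compound 4 lie, and so whether the single number of compound 3 marks any real difference. Also open is how this assay responds when a carboxylic acid or an amine takes the place of the hydroxymethyl on the shared core, as the compounds shown vary this chain only in its length and otherwise change the aryl group.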